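The source may report more compounds than this note shows. Statements on the series, on what has been measured and on what is new or still open speak of the compounds shown alone.

The series shares one core and differs in the aryl group hung on the double-bonded chain carbon. Compound 1 `C=CCn1c(=O)/c(=C\c2cccc(F)c2)[nH]c(=O)/c1=C\c1ccccc1OC` is measured in a functional assay on K562 cells (Homo sapiens) for cytotoxicity, read by CCK-8 assay, with a stated time of 72 h (on this read-out higher numbers stand for weaker inhibition and lower numbers for stronger inhibition), where compound 1 gives 4100 nM. Among the numbers reported this is the highest of the two; compound 2 `COc1ccccc1/C=c1/[nH]c(=O)/c(=C\c2nc[nH]c2C(C)(C)C)[nH]c1=O` gives 60 nM in this assay, a gap that lies well beyond the usual scatter. Compound 3 `C=CCn1c(=O)/c(=C\c2ccc(Cl)c(Cl)c2)[nH]c(=O)/c1=C\c1ccccc1OC` carries a 3,4-dichlorophenyl group and is reported in this assay as "not active" (no number reported), with no figure given.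

Compound 4 `C=CCn1c(=O)/c(=C\c2cc(Br)ccc2F)[nH]c(=O)/c1=C\c1ccccc1OC` has not yet been measured. It differs from compound 1 in one place: 5-bromo-2-fluorophenyl in place of 3-fluorophenyl on a double-bonded chain carbon bound to an aromatic carbon. Nothing in the measured set shows how this particular swap behaves, so the expectation rests on the weak number of compound 1 and the fact that the more heavily halogenated compound 3 gave no activity. On that basis the step of a 2.0-fold higher number from compound 1 to compound 4 (0.29 log units; within the scatter) is expected to point toward weaker inhibition, possibly past the limit of the assay. Compound 4 is therefore estimated at 8000 nM in this assay, within a range of 2000 nM to 40000 nM.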

Compound 4, half-maximal inhibitory concentration: 5100 nM
Compound 4: middle estimate off by 1.6-fold (0.20 log units), on the high side, within the range that was stated.
By their numbers in this assay, from the lowest: compound 2; then compounds 1 and 4 (each within the scatter of the next).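

In this assay, placing 5-bromo-2-fluorophenyl in place of 3-fluorophenyl on a double-bonded chain carbon bound to an aromatic carbon gives a 1.2-fold higher number from compound 1 to compound 4 (0.09 log units; within the scatter). Going by these compounds alone, this is the first pair in the set to isolate a single change at this position, and it shows that the position accepts the larger group, with its added bromine, without a change in the read-out beyond the scatter. A second halogen on the phenyl therefore does not by itself mean a "not active" report, with compound 3 being the halogenated case that received one. No measurement bearing on the reason for this result is available.

On these data alone, it remains open how a phenyl carrying an amine or a carboxylic acid would read at this position. As far as these compounds go, it is also open whether any aryl group on the core of compound 1 can approach compound 2 at 60 nM.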